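The source may hold more compounds than are shown below. What is called first, only, known or untested is meant among the compounds shown, and "the series" means these compounds.

Of the compounds shown here, two that share a single core have been measured: compound 1, `Cc1ccc(NC(=O)Nc2cc(C)nc3ccccc23)cc1`, and compound 2, `COc1ccc(NC(=O)Nc2cc(C)nc3ccccc23)cc1F`. In a physicochemical assay for solubility, at pH 7.4 (a lower number here means a less soluble compound, a higher number a more soluble compound), compound 1 gives 1300 nM, while in this assay compound 2 gives 2700 nM. Among the measured compounds shown here, compound 2 therefore stands highest of the two numbers so far, and its nearest neighbour, compound 1, lies far enough below it that the gap exceeds the usual scatter of such measurements. A third compound, compound 3, `COc1ccc(NC(=O)Nc2cc(C)nc3ccccc23)cc1`, has not yet been measured. It differs from compound 2 in one place only: hydrogen in place of fluoro on an aromatic carbon. For the measured compounds named here, no measured pair shows this change, so its effect on solubility is not known from these data. Since the alteration is small, one expects for compound 3 in this assay no step beyond the scatter, the expected change being a 1.1-fold higher number from compound 2 to compound 3 (0.05 log units; within the scatter). Compound 3 is thus estimated to give 3000 nM in this assay, with a likely range from 1500 nM to 6000 nM.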

Compound 3, solubility: 19800 nM
For compound 3 the middle estimate is 6.6-fold (0.82 log units) below the measured one, and the stated range ends below it.
By their numbers in this assay, from the lowest: compound 1; then compound 2; then compound 3.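

In this assay, hydrogen in place of fluoro on the aromatic carbon ortho to a methoxy group gives a 7.3-fold higher number from compound 2 to compound 3 (0.87 log units; beyond the scatter), so the loss of 1 heavy atom at this position is not a silent change. Methoxy in place of methyl on an aromatic carbon, with no fluoro in either compound, gives a 15-fold higher number from compound 1 to compound 3 (1.18 log units; beyond the scatter), so that place in the shared core also responds strongly to a single change. Nothing available beyond these numbers bears on either step.

Going by these compounds, it remains open whether chloro, an amine or a hydroxyl group on the aromatic carbon now carrying hydrogen would stay near compound 2 or near compound 3. On these data alone, it is also open whether methoxy in place of methyl would give a step of similar size with fluoro kept on the ring.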